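The source may hold more compounds than are shown below. What is called first, only, known or untested is meant among the compounds shown, and "the series" means these compounds.

In an ADME assay on HEK293 cells (Homo sapiens) for cytotoxicity, read by reporter gene assay and resazurin assay, with a stated time of 48 h (a lower number here means that less compound is tolerated, a higher number that more compound is tolerated), compound 2 `COc1c(Br)cccc1C(=O)Nc1ccccc1` is known only as a limit, > 100000 nM. Compound 1 `COc1c(Br)cc(Br)cc1C(=O)Nc1ccccc1` is also a limit, > 100000 nM. Compound 3 `COc1c(Br)cccc1C(=O)Nc1cccc(Cl)c1` is a limit as well, > 100000 nM. Compound 4 `O=C(Nc1ccccc1)c1cccc(Br)c1O` departs from compound 2 by one change, hydrogen in place of methyl on an oxygen on an aromatic ring, or methoxy to hydroxy. Two measured steps lie nearest, though both change another place: a step that the two limits leave unreadable from compound 1 to compound 2 and a step that the two limits leave unreadable from compound 2 to compound 3. Neither gives a size. Because of the limit of > 100000 nM in this assay, at which 3 of the 3 values shown sit, no step beyond the scatter is expected in this assay. The estimated step is a number no higher from compound 2 to compound 4 (the limit leaves the size open). The expected value for compound 4 is 100000 nM, within an estimated range of 30000 nM to 200000 nM.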

Compound 4, half-maximal cytotoxic concentration: 82000 nM
The estimate for compound 4 lay 1.2-fold (0.09 log units) above the measured number; the range from low to high includes it.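

Among these compounds, compound 4 is the first compound in this assay to be read as a number rather than a limit, at 82000 nM. Methoxy to hydroxy on the aromatic ring gives an at least 1.2-fold lower number from compound 2 to compound 4 (0.08 log units; that floor lies within the scatter), so this position allows a measurable value, but the change is not shown to go beyond the scatter. The full size of the step stays open because of this limit: the limit of > 100000 nM in this assay, at which 3 of the 4 values shown sit.

The compounds shown leave open what an amine or an ethoxy group would give in place of the methoxy. On these data alone, it also remains open whether hydroxy would give a number alongside the second bromo of compound 1 or the chloro of compound 3.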